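A few compounds are considered here, and "the series" means these few. Any claim that something is new, unique, unknown or untested is made for them only; others in the source may bear on it.

Measured compounds:
compound 1 `N#CC1=C(N)Oc2c(c3nc4ccccc4nc3c3ccccc23)C12C(=O)N(Cc1cnnn1-c1ccc(F)cc1)c1ccccc12`
compound 2 `Cc1ccc(C)c(-n2nncc2CN2C(=O)C3(C(C#N)=C(N)Oc4c3c3nc5ccccc5nc3c3ccccc43)c3ccccc32)c1`

In a functional assay on MCF7 cells (Homo sapiens) for antiproliferative activity, read by MTT assay, with a stated time of 48 h (a higher number here means a weaker inhibitor, a lower number a stronger inhibitor), compound 1 reaches only the assay limit > 50000 nM. In this assay compound 2 likewise reaches only the assay limit > 50000 nM. The step that the two limits leave unreadable from compound 1 to compound 2 is therefore not readable because both ends sit at the limit of > 50000 nM in this assay, at which 2 of the 2 values shown sit. For the measured compounds named here, compound 2 thus stands at a limit, not at a number, and the only other value shown is a limit as well.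

Compound 3 `N#CC1=C(N)Oc2c(c3nc4ccccc4nc3c3ccccc23)C12C(=O)N(Cc1cnnn1-c1ccc(Cl)c(Cl)c1)c1ccccc12` has not been measured in this assay. The change is 3,4-dichlorophenyl in place of 2,5-dimethylphenyl on an aromatic nitrogen. Going by the values given here, the one measured step on this aromatic nitrogen, a step that the two limits leave unreadable from compound 1 to compound 2, gives no size to carry over, so no direction can be drawn from the data. With both neighbours at the limit, compound 3 is expected to give 60000 nM, with a range from 20000 nM to 200000 nM, most likely again reported only as a limit. This amounts to an expected step that the limit leaves unreadable from compound 2 to compound 3.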

Compound 3, half-maximal inhibitory concentration: > 50000 nM
Compound 3 gave a limit, no number; the forecaster's own chance of this, stated with the estimate: 85%; the middle value is on the limit's open side.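

No new step can be read among compound 1, compound 2 and compound 3, because each value is a limit and not a number: the limit of > 50000 nM in this assay, at which 3 of the 3 values shown sit. In this assay the compounds shown leave open whether any group on this aromatic nitrogen gives a measurable number.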